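Mirror image of a urea: does the flipped centre matter?

The source may report more compounds than this note shows. Statements on the series, on what has been measured and on what is new or still open speak of the compounds shown alone.

Measured so far:
compound 1, `CC(C)c1ccccc1NC(=O)N[C@@H](C)c1ccccc1`, 99% in an ADME assay on the whole organism with Oryza sativa as the target, tested at 0.1 uM; on this read-out lower numbers stand for a stronger effect and higher numbers for a weaker effect at the one concentration tested
compound 2, `C[C@@H](NC(=O)Nc1ccccc1Br)c1ccccc1`, 99% in this assay

In this assay compound 2 stands level with compound 1 at the digits shown, within the scatter. Compound 3, `C[C@H](NC(=O)Nc1ccccc1Br)c1ccccc1`, is its mirror-image partner: the two compounds have the same atoms and bonds and differ only in configuration as drawn: 1 of 1 stereo elements differ; a stereocentre at a saturated chain carbon is drawn R in compound 2 and S in compound 3. Among the measured compounds shown here, no step between two measured compounds is available to guide the expectation, so the flip is judged only from compound 2 itself. Given the weak effect of compound 2 at 99%, a change not beyond the scatter is expected, a number 2 percentage points lower from compound 2 to compound 3 (within the scatter), and compound 3 is estimated at 97%, between 75% and 100%.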

Compound 3, a percentage reported as activity, at one concentration (the size of the read-out at that concentration, not a potency): 101%
Compound 3: middle estimate off by 4 percentage points, on the low side; measured number above the stated range.
By their numbers in this assay, from the lowest: compounds 1, 2 and 3 (each within the scatter of the next).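

Flipping the stereocentre at the saturated chain carbon gives a number 2 percentage points higher from compound 2 to compound 3 (within the scatter) in this assay, so at the one concentration tested this read-out does not separate the mirror-image pair. Bromo in place of isopropyl on an aromatic carbon gives a number 2 percentage points higher from compound 1 to compound 3 (within the scatter). The comparison of the mirror-image pair rests on a single difference: the fact that compounds 2 and 3 differ only in the configuration as drawn

All three compounds show only a weak effect, so a flip could still matter in a compound with a stronger one. Going by these compounds, whether an amine or a carboxylic acid in place of bromo would bring such an effect stays open.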